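The source may report more compounds than this note shows. Statements on the series, on what has been measured and on what is new or still open speak of the compounds shown alone.

Measured compounds in an assay on isolated protein for binding affinity to leukotriene B4 receptor 1 (Homo sapiens), tested at 1 uM; a higher number here means more inhibition at the concentration tested (going by the name of the read-out), a lower number less inhibition:
compound 1 `CCCCCCc1cc(C(C)=O)c(O)cc1OCCCCC#N` — 13%
compound 2 `CCc1cc(C(C)=O)c(O)cc1OCCCCCCCC(C)(C)C#N` — 29%
compound 3 `CC(=O)c1cc(C(C)(C)C)c(OCCCCCC(C)(C)C#N)cc1O` — 2%

Compound 2 gives the highest of the three numbers in this assay. Compound 1 sits nearest to it, with a number that is lower by more than the scatter; compound 3 lies furthest away, lower still and again beyond the scatter. No two of these compounds differ in only one place, so none of the gaps can be tied to a single change.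

Compound 4 `CCc1cc(C(C)=O)c(O)cc1OCCCCCC[S+](C)[O-]` is not yet measured. It is derived from compound 2 by a single change: a group of 3 heavy atoms (1 carbon, 1 oxygen, 1 sulfur; no ring) in place of a group of 6 heavy atoms (5 carbon, 1 nitrogen; no ring), on a saturated chain carbon, six bonds along the chain from an oxygen on an aromatic ring. The shared core of compound 2 and the rest of the chain are kept; only the end of the chain is exchanged, with the 2-cyano-2-methylpropyl group leaving and the smaller sulfur-bearing group entering.

Going by the values given here, nothing measured so far tells how the end of this chain matters in this assay, so the step is guessed from compound 2 alone. The expected step is a modest decrease, a number 9 percentage points lower from compound 2 to compound 4 (within the scatter), though a result within the scatter of compound 2 would not surprise. Compound 4 is estimated at 20% in this assay, with a plausible range from 5% to 38%.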

Compound 4, a percentage reported as inhibition, at one concentration (the size of the read-out at that concentration, not a potency): 50%
Beside the measured number, compound 4's estimate is 30 percentage points below it, and the stated range ends below it.
By their numbers in this assay, from the lowest: compound 3; then compound 1; then compound 2; then compound 4.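

In this assay, exchanging the 2-cyano-2-methylpropyl group for the smaller sulfur-bearing group, on a saturated chain carbon, six bonds along the chain from an oxygen on an aromatic ring, gives a number 21 percentage points higher from compound 2 to compound 4 (beyond the scatter). Going by these compounds alone, this is the first reading of the end of the chain on its own, since no two of the earlier compounds differ in only one place, and it shows that the read-out responds to what sits there. A nitrile at the end of the chain is also not needed for the read-out in this pair, as compound 4 carries none and gives 50%; no measurement at hand accounts for the step.

The exchange changes the size of the end group, removes the nitrile and brings in the sulfur-bearing group all at once, so a single pair cannot separate these changes; a sulfone, a carboxylic acid or an amine at the same place would help to tell them apart. Going by these compounds, whether the same exchange would raise the number on the core of compound 1 or compound 3 also remains open.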